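A few compounds are considered here, and "the series" means these few. Any claim that something is new, unique, unknown or untested is made for them only; others in the source may bear on it.

Three compounds have been measured in an ADME assay on L929 cells (Mus musculus) for cytotoxicity, read by resazurin assay, with a stated time of 48 h; on this read-out higher numbers stand for lower toxicity in this test and lower numbers for higher toxicity in this test:

- compound 1 `COC(=O)CCn1c2ccc([N+](=O)[O-])cc2c(=O)n1Cc1ccccc1`: > 256000 nM
- compound 2 `NC(=O)CCCn1c2ccc([N+](=O)[O-])cc2c(=O)n1Cc1ccccc1`: > 256000 nM
- compound 3 `CNC(=O)CCCn1c2ccc([N+](=O)[O-])cc2c(=O)n1Cc1ccccc1`: > 256000 nM

All three values are limits of the assay and not numbers. Compound 3 therefore stands at > 256000 nM, which is a limit, and the series offers only (the limit of > 256000 nM in this assay, at which 3 of the 3 values shown sit).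

The next compound is compound 4 `O=c1c2cc([N+](=O)[O-])ccc2n(CCO)n1Cc1ccccc1`. Its difference from compound 3 is hydroxy in place of (methylcarbamoyl)methyl on a saturated chain carbon, two bonds along the chain from an aromatic nitrogen. Read one bond further out, 3-(methylcarbamoyl)propyl gives way to 2-hydroxyethyl.

Among the measured compounds shown here, three measured steps bear on this change. Two alter the same chain, a step that the two limits leave unreadable from compound 1 to compound 2 and a step that the two limits leave unreadable from compound 1 to compound 3, and the third is a step that the two limits leave unreadable from compound 2 to compound 3. For the measured compounds named here, none of them has a readable size, and no measured compound carries hydroxy at this place. With compound 3 at > 256000 nM, a limit, no step beyond the usual scatter is expected in this assay, and no direction can be argued firmly.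

The expected change is a number no higher from compound 3 to compound 4 (the limit leaves the size open). For compound 4 the estimate is 256000 nM, with an expected range of 120000 nM to 512000 nM.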

Compound 4, concentration lethal to 50% of the cells: > 256000 nM
Compound 4: a limit, no number (the forecaster's own chance of this, stated with the estimate: 70%); the middle value sits exactly at the limit.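

In this assay compound 4 gives > 256000 nM, which is a limit and not a number. The steps from compound 1, compound 2 and compound 3 to compound 4 therefore cannot be read. Whether any of these chain changes shifts this read-out stays open, and the series offers only this: the limit of > 256000 nM in this assay, at which 4 of the 4 values shown sit.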